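The source may hold more compounds than are shown below. What is called first, only, known or untested is meant among the compounds shown, and "the series" means these compounds.

Working notes on the series. Compound 1 `CN(CC1=CC[C@H]2C[C@@H]1C2(C)C)Cc1ccc(Cl)cc1` carries a chloro, compound 2 `CN(CC1=CC[C@H]2C[C@@H]1C2(C)C)Cc1ccc(Br)cc1` a bromo and compound 3 `CN(CC1=CC[C@H]2C[C@@H]1C2(C)C)Cc1ccc(-c2cccc(F)c2)cc1` a 3-fluorophenyl on the same core. In an assay on HEK293 cells for displacement of a labelled ligand from C-X-C chemokine receptor type 3 (Homo sapiens) (a higher number here means a weaker inhibitor, a lower number a stronger inhibitor), compound 1 gives 2510 nM, compound 2 gives 3160 nM, and compound 3 gives 2510 nM. Compound 3 stands level with compound 1, the two together holding the lowest numbers of the three, and compound 2 sits within the scatter of both. All steps are flat: a 1.3-fold higher number from compound 1 to compound 2 (0.10 log units; within the scatter), no change at the digits printed from compound 1 to compound 3 (within the scatter) and a 1.3-fold lower number from compound 2 to compound 3 (0.10 log units; within the scatter).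

Compound 4 `COC(=O)c1cccc(-c2ccc(CN(C)CC3=CC[C@H]4C[C@@H]3C4(C)C)cc2)c1` differs from compound 3 in one place: methoxycarbonyl in place of fluoro on an aromatic carbon. Among the measured compounds shown here, no measured step exchanges a group on the 3-fluorophenyl itself; the comparisons that bear on it are the exchanges of chloro and bromo for 3-fluorophenyl, no change at the digits printed from compound 1 to compound 3 (within the scatter) and a 1.3-fold lower number from compound 2 to compound 3 (0.10 log units; within the scatter), both within the scatter. Compound 4 is therefore expected to show a 1.0-fold lower number from compound 3 to compound 4 (0.00 log units; within the scatter), with no direction beyond the scatter. For compound 4 the estimate in this assay is 2500 nM, with a range from 1000 nM to 6300 nM.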

Compound 4, inhibition constant: > 316 nM
Compound 4 was reported as a limit; the forecaster's own chance of this, stated with the estimate: 10%; the middle value is on the limit's open side.
By their numbers in this assay, from the lowest: compounds 1, 3 and 2 (each within the scatter of the next).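

In this assay compound 4 gives > 316 nM, which is a limit and not a number. Among the compounds shown here, no step from compound 3 to compound 4 can be read. The compounds shown leave open whether methoxycarbonyl in place of fluoro changes the number at all, and in which direction.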